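The source may hold more compounds than are shown below. What is called first, only, known or untested is meant among the compounds shown, and "the series" means these compounds.

In a functional assay on HepG2 cells (Homo sapiens) for antiproliferative activity, read by MTT assay, with a stated time of 72 h (a higher number here means a weaker inhibitor, a lower number a stronger inhibitor), the two measured compounds gave:
compound 1 `CCCCCc1ccc(-c2cn(C[C@H](O)[C@H]3OC(=O)C(OCc4ccccc4)=C3OCc3ccccc3)nn2)cc1`: 7460 nM
compound 2 `CCCCCCCCCCc1cn(C[C@H](O)[C@H]2OC(=O)C(OCc3ccccc3)=C2OCc2ccccc2)nn1`: 12200 nM

These two numbers sit within the scatter of each other: a 1.6-fold higher number from compound 1 to compound 2 (0.21 log units; within the scatter). Compound 3 `Cc1ccc(-c2cn(C[C@H](O)[C@H]3OC(=O)C(OCc4ccccc4)=C3OCc3ccccc3)nn2)cc1` differs from compound 2 in one place: 4-methylphenyl in place of decyl on an aromatic carbon. Within the data shown here, the only measured step that bears on this change is the one from compound 1 to compound 2, and it stayed within the scatter, so for compound 3 in this assay no shift beyond the scatter is expected: a 1.4-fold lower number from compound 2 to compound 3 (0.13 log units; within the scatter). Compound 3 is therefore estimated at about 9000 nM, with a range from 3000 nM to 30000 nM.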

Compound 3, half-maximal inhibitory concentration: 8770 nM
Compound 3: the middle estimate sits 1.0-fold (0.01 log units) above what was measured; the range from low to high includes it.
By their numbers in this assay, from the lowest: compounds 1, 3 and 2 (each within the scatter of the next).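

In this assay, a 1.4-fold lower number from compound 2 to compound 3 (0.14 log units; within the scatter) comes with 4-methylphenyl replacing decyl on this aromatic carbon, and a 1.2-fold higher number from compound 1 to compound 3 (0.07 log units; within the scatter) comes with a methyl in place of the pentyl chain on the phenyl ring. So among these three compounds, neither an open chain versus a ring at this position nor the length of the chain on that ring separates the values beyond the scatter. Nothing available explains this result. From the compounds shown here alone, whether an amine or a carboxylic acid on this carbon would move the number remains open.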